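This account rests on a few compounds, and the source may have more. Where it says the series, first, only, none or still open, it means among the compounds named here.

Series notes. Compound 1 `CC(C)N(Cc1cccc(OCCCCCC(=O)O)c1)C(=O)c1ccc(-c2cccc(N(C)C)c2)cc1` and compound 2 `CC(=O)Nc1cccc(-c2ccc(C(=O)N(Cc3cccc(OCCCCCC(=O)O)c3)C(C)C)cc2)c1` share one core and differ only in the group on an aromatic carbon. In an ADME assay on HepG2 cells (Homo sapiens) for cytotoxicity, read by CellTiter-Glo and resazurin assay, with a stated time of 72 h (a higher number here means that more compound is needed for the effect, a lower number that less compound is needed), compound 1 gives > 26000 nM, which is a limit of the assay. In this assay compound 2 likewise gives > 26000 nM, again a limit. The step that the two limits leave unreadable from compound 1 to compound 2 therefore cannot be read, and compound 2 stands at the limit of > 26000 nM in this assay, at which 2 of the 2 values shown sit. Compound 3 `CC(=O)c1cccc(-c2ccc(C(=O)N(Cc3cccc(OCCCCCC(=O)O)c3)C(C)C)cc2)c1` follows from compound 2 by acetyl in place of acetamido on an aromatic carbon. Among the compounds with values here, no measured step bears on this change; the single recorded step is unreadable. Compound 3 is therefore expected to stay at or past the limit, with the step that the limit leaves unreadable from compound 2 to compound 3 estimated as not beyond the scatter. For compound 3 the estimate is 40000 nM, between 15000 nM and 110000 nM.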

Compound 3, half-maximal effective concentration: > 26000 nM
Compound 3 gave a limit, no number; the forecaster's own chance of this, stated with the estimate: 80%; the middle value does not contradict the limit.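

In this assay compound 3 gives > 26000 nM, a limit. The steps to compound 3 from compound 1 and compound 2 therefore cannot be read. Still open is whether the group on the aromatic carbon changes this read-out at all, as all three compounds stop at the same point: the limit of > 26000 nM in this assay, at which 3 of the 3 values shown sit.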